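A few compounds are considered here, and "the series" means these few. Any claim that something is new, unique, unknown or untested is made for them only; others in the source may bear on it.

Compound 1 `CCO/C(O)=C1\C(COCCNc2noc(N)n2)=NC(C)=C(C(=O)OC)C1c1cccc(Cl)c1Cl`: 3.16 nM
Compound 2 `CCOC(=O)NC(=S)NCCOCC1=C(C(=O)OCC)C(c2cccc(Cl)c2Cl)/C(=C(\O)OC)C(C)=N1`: 31.6 nM
Compound 3 `CCO/C(O)=C1\C(COCCNc2nc(O)cc(-c3ccccc3)n2)=NC(C)=C(C(=O)OC)C1c1cccc(Cl)c1Cl`: 7.94 nM

In a functional assay (aorta) with Rattus norvegicus as the target (on this read-out higher numbers stand for weaker inhibition and lower numbers for stronger inhibition), compound 1 holds the lowest number of the three, and both of its steps to the others lie beyond the scatter, so it is the strongest inhibitor shown here. Compound 4 `CCO/C(O)=C1\C(COCCNc2n[s+]([O-])nc2OC)=NC(C)=C(C(=O)OC)C1c1cccc(Cl)c1Cl` has not been measured in this assay. It differs from compound 1 in one place: a group of 8 heavy atoms (3 carbon, 2 nitrogen, 2 oxygen, 1 sulfur; one five-membered aromatic ring with 3 hetero atoms) in place of a group of 6 heavy atoms (2 carbon, 3 nitrogen, 1 oxygen; one five-membered aromatic ring with 3 hetero atoms), on an amine nitrogen. Going by the values given here, no pair of measured compounds shows this change, so the measured numbers give no direct guide to its size. The author expects a modest weakening, with the step from compound 1 to compound 4 estimated at a 2.0-fold higher number from compound 1 to compound 4 (0.30 log units; within the scatter), close to the edge of the scatter. Compound 4 is therefore estimated at 6.3 nM, with a range from 2 nM to 20 nM.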

Compound 4, half-maximal inhibitory concentration: 10 nM
Beside the measured number, compound 4's estimate is 1.6-fold (0.20 log units) below it; the measured number falls inside the stated range.
By their numbers in this assay, from the lowest: compound 1; then compounds 3 and 4 (each within the scatter of the next); then compound 2.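

In this assay, this is the first step shown at the group on the amine nitrogen: exchanging the 5-amino-1,2,4-oxadiazol-3-yl group for the sulfur-containing ring gives a 3.2-fold higher number from compound 1 to compound 4 (0.50 log units; beyond the scatter). The position therefore responds to a change between two five-membered aromatic rings, each with 3 hetero atoms, although the effect is modest. The entering group has 0 hydrogen-bond donors in place of 1 and more heavy atoms, and no measurement here explains the step.

A single step cannot separate these two differences. On these data alone, whether a plain phenyl or an acetyl group on this nitrogen would give a lower or higher number remains open.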